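The source may report more compounds than this note shows. Statements on the series, on what has been measured and on what is new or still open speak of the compounds shown alone.

In an assay on HEK293 cells for binding affinity to 5-hydroxytryptamine receptor 7 (Homo sapiens), read by radioligand binding, tested at 1 uM (a lower number here means less inhibition, a higher number more inhibition at the concentration tested (going by the name of the read-out)), compound 1 `Brc1cccc2ccn(CCN3CCN4CCCCC4C3)c12` gives 13%, and compound 2 `CN1CCCN(CCn2ccc3ccc(O)cc32)CC1` gives 28%. For the measured compounds named here, compound 2 thus stands highest of the two numbers measured so far, with compound 1 lying beyond the scatter below it. Going by the values given here, these two differ in more than one place, so no single step can be drawn from them. Compound 3 `CC(C)c1ccc2ccn(CCN3CCCN(C)CC3)c2c1` follows from compound 2 by one change, (isopropyl in place of hydroxy on an aromatic carbon). Among the compounds with values here, no measured pair shows this change, so its effect is unknown. The step of a number 10 percentage points lower from compound 2 to compound 3 (within the scatter) is expected to be a decrease, though not clearly beyond the scatter. Compound 3 is estimated at 18%, within 0% to 40%.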

Compound 3, a percentage reported as inhibition, at one concentration (the size of the read-out at that concentration, not a potency): 72%
For compound 3 the middle estimate is 54 percentage points below the measured one; the measured number lies above the stated range.
By their numbers in this assay, from the lowest: compound 1; then compound 2; then compound 3.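

Isopropyl in place of hydroxy on this aromatic carbon gives a number 44 percentage points higher from compound 2 to compound 3 (beyond the scatter) in this assay, the first step in the series that can be read at a single place. This carbon of the shared core is therefore not indifferent to its substituent, and the change here moves the read-out well past the scatter. Nothing at hand accounts for the size of this step.

Open, on these data alone, is whether methoxy, a chlorine atom or tert-butyl on the same carbon would read nearer compound 2 or compound 3. The step is also shown only with the side chain shared by compound 2 and compound 3, and not with that of compound 1.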